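Swapping chloro and methyl on the anilino ring of compound 2

The source may hold more compounds than are shown below. What is called first, only, known or untested is meant among the compounds shown, and "the series" means these compounds.

Measured compounds:
Compound 1, `CN(c1cccc2c1CN(c1nc(Nc3cc(C(F)(F)F)cc(C(F)(F)F)c3)ncc1C(F)(F)F)C2)S(C)(=O)=O`: 9200 nM
Compound 2, `Cc1cc(Cl)ccc1Nc1ncc(C(F)(F)F)c(N2Cc3cccc(N(C)S(C)(=O)=O)c3C2)n1`: 17400 nM
Compound 3, `COc1ccc(C(F)(F)F)cc1Nc1ncc(C(F)(F)F)c(N2Cc3cccc(N(C)S(C)(=O)=O)c3C2)n1`: 17200 nM

In a functional assay on HeLa cells (Homo sapiens) for antiproliferative activity, read by spectrophotometry, with a stated time of 2 days (on this read-out lower numbers stand for stronger inhibition of growth and higher numbers for weaker inhibition of growth), compound 2 gives 17400 nM, compound 3 gives 17200 nM and compound 1 gives 9200 nM. The three numbers lie within the usual scatter of one another, so compound 2 cannot be set apart from compound 3 or from compound 1 on these data; the shared core carries the activity, and the anilino group has so far made no difference that can be trusted.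

Compound 4, `Cc1ccc(Nc2ncc(C(F)(F)F)c(N3Cc4cccc(N(C)S(C)(=O)=O)c4C3)n2)c(Cl)c1`, has not been measured. It differs from compound 2 in one place: 2-chloro-4-methylphenyl in place of 4-chloro-2-methylphenyl on a nitrogen on an aromatic ring

Going by the values given here, the only measured step that touches the same position is the one from compound 2 to compound 3, which reads a 1.0-fold lower number from compound 2 to compound 3 (0.01 log units; within the scatter). That step changes the aryl group far more than the rearrangement leading to compound 4 does, and it still stayed within the scatter. Among the compounds with values here, no measured pair shows the exact exchange of chloro and methyl positions, so the expectation rests on the insensitivity seen so far. Compound 4 is therefore expected to sit close to compound 2, with an estimated step of a 1.2-fold lower number from compound 2 to compound 4 (0.06 log units; within the scatter), which is no change beyond the scatter. The estimate for compound 4 in this assay is 15000 nM, within a range from 5000 nM to 45000 nM.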

Compound 4, concentration for 50% growth inhibition: 10900 nM
Compound 4: the middle estimate sits 1.4-fold (0.14 log units) above what was measured; low and high end bracket the measured number.
By their numbers in this assay, from the lowest: compounds 1, 4, 3 and 2 (each within the scatter of the next).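

In this assay, moving from 4-chloro-2-methylphenyl to 2-chloro-4-methylphenyl on this nitrogen gives a 1.6-fold lower number from compound 2 to compound 4 (0.20 log units; within the scatter). Going by these compounds alone, this is the first direct test on this position in which the same atoms are only rearranged, and that rearrangement does not separate the two compounds, which extends what the far larger aryl change between compound 2 and compound 3 had suggested. The comparison of two quite different aryl groups reads a 1.6-fold lower number from compound 3 to compound 4 (0.20 log units; within the scatter), so 2-chloro-4-methylphenyl joins the other aryl groups here that cannot be told apart on these numbers, and nothing independent of them is available to explain this lack of separation.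

It remains open whether any group on the phenyl ring can move the number beyond the scatter, for instance an amine or a carboxylic acid, neither of which appears among the compounds shown, or whether a plain unsubstituted phenyl would read the same. As far as these compounds go, it is also open whether the rest of the shared core matters more than this ring, for example with a nitrile in place of its trifluoromethyl.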